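Moving a Nitro Group Around a Sulfonamide Ring

The source may hold more compounds than are shown below. What is called first, only, known or untested is meant among the compounds shown, and "the series" means these compounds.

Going by the values given here, compound 2 `CCOC(=O)c1oc2ccc(NS(=O)(=O)c3cccc([N+](=O)[O-])c3)cc2c1C` gives 30100 nM in a functional assay on MDA-MB-468 cells (Homo sapiens) for antiproliferative activity, read by MTT assay, with a stated time of 72 h (on this read-out lower numbers stand for stronger inhibition and higher numbers for weaker inhibition), the lowest of the two numbers so far. Compound 1 `CCOC(=O)c1oc2ccc(NS(=O)(=O)c3ccccc3C)cc2c1C` gives 53400 nM in this assay, and the step of a 1.8-fold lower number from compound 1 to compound 2 (0.25 log units; within the scatter) stays within the scatter. Compound 3 `CCOC(=O)c1oc2ccc(NS(=O)(=O)c3ccccc3[N+](=O)[O-])cc2c1C` differs from compound 2 in one place: 2-nitrophenyl in place of 3-nitrophenyl on a sulfonyl sulfur. No measured step moves a nitro group from one position to another on this ring; the only step shown, 2-methylphenyl to 3-nitrophenyl, was small. The expected step is therefore a 1.0-fold lower number from compound 2 to compound 3 (0.00 log units; within the scatter), with no direction beyond the scatter. The estimate for compound 3 is 30000 nM, ranging from 10000 nM to 90000 nM.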

Compound 3, half-maximal inhibitory concentration: 96900 nM
For compound 3 the middle estimate is 3.2-fold (0.51 log units) below the measured one; measured number outside the range, above it.
By their numbers in this assay, from the lowest: compounds 2, 1 and 3 (each within the scatter of the next, the first and the last beyond it).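

In this assay, 2-nitrophenyl in place of 3-nitrophenyl on a sulfonyl sulfur gives a 3.2-fold higher number from compound 2 to compound 3 (0.51 log units; beyond the scatter); the two compounds have the same atoms joined differently, so the placement of the nitro group alone changes the number, though only modestly. Nitro in place of methyl on an aromatic carbon gives a 1.8-fold higher number from compound 1 to compound 3 (0.26 log units; within the scatter), a step that cannot be told apart from the scatter. Nothing measured here explains the effect of moving the nitro group.
Still open, going by these compounds, is whether an amine or a carboxylic acid in place of the nitro group on this ring would give a lower number.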